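Removing the fluorobenzoyl group from compound 2

The compounds below may be only part of what the source reports. "The series", "measured", "known", "first", "only" and "open" are said of these compounds alone.

- compound 1 `COc1ccc(S(=O)(=O)N2CCc3cccc(NC(=O)c4ccc([N+](=O)[O-])cc4)c32)cc1` gives 102 nM
- compound 2 `COc1ccc(S(=O)(=O)N2CCc3cccc(NC(=O)c4ccc(F)cc4)c32)cc1` gives 93 nM
- compound 3 `COc1ccc(S(=O)(=O)N2CCc3cc(Br)cc(NC(=O)c4ccncc4)c32)cc1` gives 91 nM

In a functional assay on KB cells (Homo sapiens) for cytotoxicity (on this read-out higher numbers stand for weaker inhibition and lower numbers for stronger inhibition), compound 2 gives 93 nM and stands level with compound 1 and compound 3, since all three numbers lie within the usual scatter of one another. Compound 4 `COc1ccc(S(=O)(=O)N2CCc3cccc(N)c32)cc1` has not been measured yet and differs from compound 2 in one place (hydrogen in place of (4-fluorophenyl)carbonyl on a nitrogen on an aromatic ring), with hydrogen in place of (4-fluorophenyl)carbonyl on a nitrogen on an aromatic ring.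

Going by the values given here, the only measured single change is a 1.1-fold lower number from compound 1 to compound 2 (0.04 log units; within the scatter) and it offers little guidance, as it swaps nitro for fluoro and keeps the carbonyl. Among the compounds with values here, all three measured compounds carry a carbonyl on that nitrogen, so the data hold no direct precedent for losing it. Removing a whole group is a far larger change than that swap, and a higher number, beyond the scatter, is expected in this assay with much uncertainty in its size. The expected change is an 8.6-fold higher number from compound 2 to compound 4 (0.93 log units; beyond the scatter) on this estimate. For compound 4 the estimated value is 800 nM with 150 nM to 5000 nM as the expected range.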

Compound 4, half-maximal inhibitory concentration: 2800 nM
The estimate for compound 4 lay 3.5-fold (0.54 log units) below the measured number, and the stated range covers the measured number.
By their numbers in this assay, from the lowest: compounds 3, 2 and 1 (each within the scatter of the next); then compound 4.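

In this assay, going by these compounds alone, the loss of the whole group gives a 30-fold higher number from compound 2 to compound 4 (1.48 log units; beyond the scatter), the first large step. The earlier swap of nitro for fluoro, seen as a 1.1-fold lower number from compound 1 to compound 2 (0.04 log units; within the scatter), kept a carbonyl on this nitrogen, so only now does it emerge that the number depends strongly on having an acyl group there at all. Nothing available explains this rise.

The whole (4-fluorophenyl)carbonyl left in one step, so the compounds shown do not separate the part played by the carbonyl from that of the aromatic ring it carries. An acetyl group on this nitrogen would keep the carbonyl without the ring, while a benzyl group would keep the ring without the carbonyl, and either could help to tell the two apart.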